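The source may report more compounds than this note shows. Statements on the series, on what has been measured and on what is new or still open speak of the compounds shown alone.

Three compounds share one core and differ only in the group attached to the aromatic ring. Compound 1 `CCN(CC)CCNC(=O)C1CC(C(CC)(CC)c2ccc(C#CC(C)(O)CC)c(C)c2)=CN1CC` carries a 1-hydroxy-1-methylpropyl group on a triple-bonded carbon, and in an assay on isolated protein for binding affinity to vitamin D3 receptor (Homo sapiens), read by fluorescence polarization, tested at 1 uM (on this read-out lower numbers stand for less inhibition and higher numbers for more inhibition at the one concentration tested (going by the name of the read-out)), compound 1 gives 59.2%. Within the data shown here, compound 2 `CCN(CC)CCNC(=O)C1CC(C(CC)(CC)c2ccc(C#CC(O)C3CCCCC3)c(C)c2)=CN1CC` gives 44.2% in this assay, and the change a number 15 percentage points lower from compound 1 to compound 2 (beyond the scatter) is the only measured step. Compound 3 `C#Cc1ccc(C(CC)(CC)C2=CN(CC)C(C(=O)NCCN(CC)CC)C2)cc1C` carries a bare ethynyl group, and in this assay compound 3 is reported as "not active" (no number reported), with no number given. Compound 4 `CCN(CC)CCNC(=O)C1CC(C(CC)(CC)c2ccc(/C=C/C(O)(CC)CC)c(C)c2)=CN1CC` differs from compound 3 by a group of 8 heavy atoms (7 carbon, 1 oxygen; no ring) in place of a group of 2 heavy atoms (2 carbon; no ring), on an aromatic carbon. The hydroxyl-bearing groups of compound 1 and compound 2 give measurable inhibition while compound 3 does not, and compound 4 also bears a hydroxyl, so moderate inhibition is expected. The estimate for compound 4 is 50%, between 25% and 72%.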

Compound 4, a percentage reported as inhibition, at one concentration (the size of the read-out at that concentration, not a potency): 65.5%
For compound 4 the middle estimate is 15.5 percentage points below the measured one; the range from low to high includes it.
By their numbers in this assay, from the lowest: compound 2; then compounds 1 and 4 (each within the scatter of the next).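

This position accepts a double bond as well as a triple bond in a hydroxyl-bearing group without a ring: the swap gives a number 6.3 percentage points higher from compound 1 to compound 4 (within the scatter) and so the two compounds read alike. Set against the group with the six-membered ring, the same change gives a number 21.3 percentage points higher from compound 2 to compound 4 (beyond the scatter) and leaves compound 2 the lowest of the three compounds with numbers. Nothing measured here says why these numbers differ. Compound 1 and compound 4 differ in both the bond and the size of the group, so the effect of the bond alone stays unresolved. As far as these compounds go, whether an amine in place of the hydroxyl, or a longer chain, would keep this inhibition also stays open.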